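A few compounds are considered here, and "the series" means these few. Any claim that something is new, unique, unknown or untested is made for them only; others in the source may bear on it.

The measured compounds:
compound 1 `O=C(CCC1=CCCN(CCCCc2ccc(-c3ccccc3)cc2)C1=O)NO`, which in a functional assay on HCT-15 cells (Homo sapiens) for inhibition, read by sulforhodamine B assay (on this read-out higher numbers stand for weaker inhibition of growth and lower numbers for stronger inhibition of growth), gives 4560 nM;
compound 2 `Cc1cccc(CN2CCC=C(CCC(=O)NO)C2=O)c1`, for which this assay reports only a limit, > 10000 nM;
compound 3 `O=C(CCC1=CCCN(Cc2ccc(F)cc2)C1=O)NO`, which in this assay gives 9960 nM.

Compound 2 thus stands at the weak end of what is shown, at the limit of > 10000 nM in this assay, at which 1 of the 3 values shown sits. Compound 4 `COc1cccc(CN2CCC=C(CCC(=O)NO)C2=O)c1` differs from compound 2 by one change, (methoxy in place of methyl on an aromatic carbon). Among the compounds with values here, the only measured step that starts from compound 2 is a number no higher from compound 2 to compound 3 (the limit leaves the size open), and its size is not readable. Within the data shown here, no measured step exchanges methyl for methoxy, so no size can be drawn from the data for this change. Compound 4 is therefore expected to stay close to compound 2, with a step that the limit leaves unreadable from compound 2 to compound 4 and a limit again likely. Compound 4 is estimated at 12000 nM, between 5000 nM and 30000 nM.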

Compound 4, concentration for 50% growth inhibition: 9030 nM
The estimate for compound 4 lay 1.3-fold (0.12 log units) above the measured number, within the range that was stated.
By their numbers in this assay, from the lowest: compounds 1, 4 and 3 (each within the scatter of the next, the first and the last beyond it). At a limit, above all of these: compound 2.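

In this assay, methoxy in place of methyl on an aromatic carbon, meta to a large group, gives an at least 1.1-fold lower number from compound 2 to compound 4 (0.04 log units; that floor lies within the scatter). Going by these compounds, compound 2 stands only at a limit of the assay: the limit of > 10000 nM in this assay, at which 1 of the 4 values shown sits. The methoxy compound therefore gives a readable number at this position, but the true size of the change stays unknown and may be no larger than the scatter.

On these data alone, whether an amine or a carboxylic acid on this aromatic carbon would give a number apart from that of compound 4 stays open. So does the outcome with a longer chain there, such as ethoxy.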